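Series notes: heteroaryl swap from compound 1 to compound 3

This account rests on a few compounds, and the source may have more. Where it says the series, first, only, none or still open, it means among the compounds named here.

Compound 1 `CN(C)c1ccc(C(=O)N[C@H]2CCC[C@H](NC(=O)c3cccc(Cl)c3)C2)cc1` gives the lower of the two numbers in a functional assay on HEK293 cells for antagonist activity at metabotropic glutamate receptor 5 (Homo sapiens), read by FLIPR and calcium flux (on this read-out higher numbers stand for weaker inhibition and lower numbers for stronger inhibition), at 473 nM. Compound 2 `O=C(N[C@H]1CCC[C@H](NC(=O)c2ccccn2)C1)c1ccccn1` gives 1150 nM in this assay, a weaker result beyond the scatter, though the two structures differ in more than one place. Compound 3 `Cc1cccnc1C(=O)N[C@H]1CCC[C@H](NC(=O)c2cccc(Cl)c2)C1` is not yet measured; it differs from compound 1 by 3-methylpyridin-2-yl in place of 4-(dimethylamino)phenyl on a carbonyl carbon. Going by the values given here, no single-change step between measured compounds exists. Given compound 2 at 1150 nM, a modest loss is expected with a 1.9-fold higher number from compound 1 to compound 3 (0.28 log units; within the scatter). Compound 3 is expected to give 900 nM, between 300 nM and 3000 nM.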

Compound 3, half-maximal inhibitory concentration: 7840 nM
Compound 3: the middle estimate sits 8.7-fold (0.94 log units) below what was measured; the measured number lies above the stated range.
By their numbers in this assay, from the lowest: compound 1; then compound 2; then compound 3.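

In this assay, the step of a 17-fold higher number from compound 1 to compound 3 (1.22 log units; beyond the scatter) shows that activity depends strongly on the aromatic group on this carbonyl carbon, with the rest of compound 1 unchanged. Replacing 4-(dimethylamino)phenyl with 3-methylpyridin-2-yl leaves the hydrogen-bond donor and acceptor counts of the group the same, so those counts do not account for the loss.

Going by these compounds alone, the single step cannot separate the ring nitrogen from the methyl, or show whether losing dimethylamino matters; 3-methylphenyl and 4-methoxyphenyl at this place would address those questions. No available evidence bears on the cause of this loss.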